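The compounds below may be only part of what the source reports. "The series", "measured", "known", "first", "only" and "open" are said of these compounds alone.

Measured compounds:
Compound 1, `COc1ccc(-c2nc(N3CCNCC3)nc3ccccc23)c(OC)c1`: 50 ug/mL
Compound 2, `Cn1cc(-c2nc(N3CCNCC3)nc3ccccc23)c2ccccc21`: 50 ug/mL

The two measured compounds share one core, each carrying a different aromatic group on it. In a functional assay on DU-145 cells (Homo sapiens) for antiproliferative activity, read by MTT assay (a lower number here means a stronger inhibitor, a higher number a weaker inhibitor), compound 1 gives 50 ug/mL. Compound 2, in this assay, gives 50 ug/mL. Compound 1 therefore stands level with compound 2 at the digits reported; the two values lie within the usual scatter of each other, so no order between them can be drawn, and neither can be called the stronger.

Compound 3, `COc1cc(OC)c(-c2nc(N3CCNCC3)nc3ccccc23)c(OC)c1`, is not yet measured. It differs from compound 1 in one place: methoxy in place of hydrogen on an aromatic carbon. Going by the values given here, no measured pair in this set differs by a change of this kind, so there is no step on record to lean on. What the two measured values do show is that two rather different aromatic groups on the same core both come out at the same reading in this assay. The step of no change at the digits printed from compound 1 to compound 3 (within the scatter) is expected to be none beyond the scatter. Compound 3 is accordingly estimated at 50 ug/mL, with a range from 20 ug/mL to 100 ug/mL.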

Compound 3, half-maximal inhibitory concentration: 50 ug/mL
The estimate for compound 3 equals the measured number at the digits printed, and the stated range covers the measured number.
By their numbers in this assay, from the lowest: compounds 1, 2 and 3 (each within the scatter of the next).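

In this assay, going by these compounds alone, the first step on record between two compounds differing in one place reads no change at the digits printed from compound 1 to compound 3 (within the scatter) for methoxy in place of hydrogen on an aromatic carbon. The added methoxy sits ortho to a large group on a ring that already carries two methoxy groups, so this position accepts that group with no shift in the reading, whereas the earlier pair, compound 1 and compound 2, differed in the whole aromatic group and could not speak to a single position or a single change. Nothing at hand accounts for this flat reading, and the step alone cannot supply a reason.

What the compounds shown leave open is whether this position would stay level with a group of another kind, such as a hydroxyl, an amine, a carboxylic acid or a longer chain like butoxy, in place of the hydrogen of compound 1. They also leave open whether either of the two methoxy groups of compound 1 contributes to the reading, since a hydrogen in place of one of them does not appear here.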